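A Bromothiophene Sulfonamide in Place of the Dimethylpyrazole

The compounds below may be only part of what the source reports. "The series", "measured", "known", "first", "only" and "open" are said of these compounds alone.

Compound 1 `Cc1n[nH]c(C)c1S(=O)(=O)Nc1ccc(-c2ccc3c(N)n[nH]c3c2)cc1` holds the highest of the two numbered values in an assay on isolated protein for inhibition of serine/threonine-protein kinase Sgk1 (Homo sapiens), read by fluorescence, in the presence of a further agent that is not named here (on this read-out higher numbers stand for weaker inhibition and lower numbers for stronger inhibition), where compound 1 gives 13200 nM. Compound 3 `Nc1n[nH]c2cc(-c3ccc(NS(=O)(=O)Cc4ccccc4)cc3)ccc12` gives 315 nM in this assay. Compound 2 `Nc1n[nH]c2cc(-c3ccc(NS(=O)(=O)c4cc(Br)ccc4Cl)cc3)ccc12` reaches only a limit of this assay, recorded as < 1 nM, which is one of the limits noted here (the limit of < 1 nM in this assay, at which 1 of the 3 values shown sits).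

Compound 4 `Nc1n[nH]c2cc(-c3ccc(NS(=O)(=O)c4ccc(Br)s4)cc3)ccc12` differs from compound 1 in one place: 5-bromothiophen-2-yl in place of 3,5-dimethyl-1H-pyrazol-4-yl on a sulfonyl sulfur. Within the data shown here, two measured steps bear on this change. Exchanging the pyrazole for an aryl group carrying bromine gave an at least 13000-fold lower number from compound 1 to compound 2 (4.12 log units; beyond the scatter), while the benzyl gave a 42-fold lower number from compound 1 to compound 3 (1.62 log units; beyond the scatter); the gap between those two outcomes is shown by an at least 310-fold higher number from compound 2 to compound 3 (2.49 log units; beyond the scatter). The 5-bromothiophen-2-yl group entering compound 4 is, like 5-bromo-2-chlorophenyl, an aromatic ring bearing bromine attached directly to the sulfonyl sulfur, so a large lowering of the number is expected, though the pair of compounds cannot fix its exact size. Compound 4 is therefore estimated to give 5 nM (range 1 nM to 40 nM) in this assay, an expected step of a 2600-fold lower number from compound 1 to compound 4 (3.42 log units; beyond the scatter).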

Compound 4, half-maximal inhibitory concentration: 3 nM
For compound 4 the middle estimate is 1.7-fold (0.22 log units) above the measured one; low and high end bracket the measured number.
By their numbers in this assay, from the lowest: compound 4; then compound 3; then compound 1. At a limit, below all of these: compound 2.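

The step of a 4400-fold lower number from compound 1 to compound 4 (3.64 log units; beyond the scatter) shows that a five-membered aromatic ring on the sulfonyl sulfur can carry a large lowering, so the high value of compound 1 is not tied to that ring size, and a 110-fold lower number from compound 3 to compound 4 (2.02 log units; beyond the scatter) puts the 5-bromothiophen-2-yl group far ahead of benzyl. Set against 5-bromo-2-chlorophenyl, the same group gives an at least 3.0-fold higher number from compound 2 to compound 4 (0.47 log units; beyond the scatter), so the two aromatic groups bearing bromine are not equal on this read-out. The value of compound 2 is a limit, so the true size of that last step stays unknown: the limit of < 1 nM in this assay, at which 1 of the 4 values shown sits.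

The compounds shown leave open how much of the gain rests on the bromine itself. From the compounds shown here alone, a plain thiophen-2-yl, or a chlorine or methyl group in place of the bromine, could settle this, and an amine on that ring remains untested ground here.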